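Trading methoxy for methylsulfonyl: an expected cytotoxicity for compound 4

A few compounds are considered here, and "the series" means these few. Any claim that something is new, unique, unknown or untested is made for them only; others in the source may bear on it.

Measured compounds:
compound 1, `COc1ccc(-c2csc(N3N=C(c4ccc(C)s4)CC3c3ccc(F)cc3)n2)cc1`, 147 ug/mL
compound 2, `Fc1ccc(C2CC(c3ccc(Cl)s3)=NN2c2nc(-c3ccc(C(F)(F)F)cc3)cs2)cc1`, > 500 ug/mL
compound 3, `Fc1ccc(C2CC(c3ccc(Cl)s3)=NN2c2nc(-c3ccc(Cl)cc3)cs2)cc1`, > 500 ug/mL

Among the compounds with values here, in an ADME assay on NIH3T3 cells (Mus musculus) for cytotoxicity, read by XTT assay, with a stated time of 24 h (on this read-out lower numbers stand for stronger inhibition and higher numbers for weaker inhibition), compound 1 gives 147 ug/mL, the only plain number among the three values shown. Compound 2 sits at > 500 ug/mL, which is a limit of the assay and not a number. Compound 3 likewise sits at > 500 ug/mL, again a limit of the assay. Within the data shown here, the one recorded step, a step that the two limits leave unreadable from compound 2 to compound 3, is therefore unreadable in size. Among the measured compounds shown here, the only evidence on the measured steps is the limit of > 500 ug/mL in this assay, at which 2 of the 3 values shown sit.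

Compound 4, `Cc1ccc(C2=NN(c3nc(-c4ccc(S(C)(=O)=O)cc4)cs3)C(c3ccc(F)cc3)C2)s1`, has not yet been measured in this assay. It differs from compound 1 by methylsulfonyl in place of methoxy on an aromatic carbon. For the measured compounds named here, no measured step involves this change, and the single step that is recorded cannot be read, so the expectation rests on compound 1 alone and carries a wide range. Compound 4 is expected to give 200 ug/mL, estimated between 70 ug/mL and 500 ug/mL. This estimate amounts to an expected step of a 1.4-fold higher number from compound 1 to compound 4 (0.13 log units; within the scatter), and a substantial chance remains that only a limit is reported.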

Compound 4, half-maximal inhibitory concentration: 374 ug/mL
Compound 4: the middle estimate sits 1.9-fold (0.27 log units) below what was measured; the range from low to high includes it.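

Within the data shown here, this is the first step that can be read: in this assay, placing methylsulfonyl in place of methoxy on an aromatic carbon, para to a large group, gives a 2.5-fold higher number from compound 1 to compound 4 (0.41 log units; beyond the scatter). The position is therefore not silent, since this single change moves the number beyond the scatter, towards weaker inhibition. Compound 4 also still gives a plain number, 374 ug/mL, while the only other step shown cannot be read: the limit of > 500 ug/mL in this assay, at which 2 of the 4 values shown sit.

With one readable step, the compounds shown leave open whether the same change would shift the number to a similar extent on another core. They also leave open what an amine, a carboxylic acid or a longer chain would give at this position.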